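The compounds below may be only part of what the source reports. "The series", "measured", "known", "first", "only" and "open" are said of these compounds alone.

Three compounds have been measured in an ADME assay on PC-3 cells (Homo sapiens) for cytotoxicity, read by WST assay, tested at 100 uM; a lower number here means less inhibition, a higher number more inhibition at the concentration tested (going by the name of the read-out):

Compound 1 `O=C(Nc1cccc(N2CCCC2=O)c1)C1CCCN(C(=O)c2cc(C(F)(F)F)cc(C(F)(F)F)c2)C1`: 0%
Compound 2 `CSc1cccc(NC(=O)C2CCCN(C(=O)c3cc(C(F)(F)F)cc(C(F)(F)F)c3)C2)c1`: 0%
Compound 3 `O=C(Nc1cccc(S(=O)(=O)N2CCCC2)c1)C1CCCN(C(=O)c2cc(C(F)(F)F)cc(C(F)(F)F)c2)C1`: 0%

All three share the same core and differ only in one group on an aromatic carbon. Compound 3 stands level with the other two: the step of no change at the digits printed from compound 1 to compound 3 (within the scatter) and the step of no change at the digits printed from compound 2 to compound 3 (within the scatter) both stay within the scatter, as does the step of no change at the digits printed from compound 1 to compound 2 (within the scatter). In short, none of the three swaps at this position moved the read-out at all, and every one of these compounds sits at the bottom of the scale.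

Compound 4 `O=C(Nc1cccc(Oc2nccc(C(F)(F)F)c2Cl)c1)C1CCCN(C(=O)c2cc(C(F)(F)F)cc(C(F)(F)F)c2)C1` carries the next swap at the same position: (3-chloro-4-(trifluoromethyl)pyridin-2-yl)oxy in place of (pyrrolidin-1-yl)sulfonyl on an aromatic carbon. The three measured steps bear on it directly, since each of them also exchanged the group at this aromatic carbon, and each was flat. The group that enters is larger than any tried so far and brings a second aromatic ring, so the comparison is looser than before, but nothing measured points to a rise. The expected step is therefore a number 2 percentage points higher from compound 3 to compound 4 (within the scatter), that is, none beyond the scatter. Compound 4 is estimated at 2%, with a range from 0% to 15%.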

Compound 4, a percentage reported as inhibition, at one concentration (the size of the read-out at that concentration, not a potency): 0%
The estimate for compound 4 lay 2 percentage points above the measured number; the range from low to high includes it.
By their numbers in this assay, from the lowest: compounds 1, 2, 3 and 4 (each within the scatter of the next).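

In this assay, the group on this aromatic carbon grows from (pyrrolidin-1-yl)sulfonyl with 8 heavy atoms to (3-chloro-4-(trifluoromethyl)pyridin-2-yl)oxy with 12 heavy atoms, and a six-membered aromatic ring replaces a five-membered non-aromatic one, yet the result is no change at the digits printed from compound 3 to compound 4 (within the scatter) in this read-out. The comparisons with the two other groups at this position agree, with no change at the digits printed from compound 2 to compound 4 (within the scatter) against methylsulfanyl and no change at the digits printed from compound 1 to compound 4 (within the scatter) against 2-oxopyrrolidin-1-yl, so across these four compounds even a group carrying a second aromatic ring, chlorine and fluorine leaves the read-out at the bottom of the scale. No measurement at hand offers a reason for this flat result.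

All four compounds share the same core and sit at the bottom of the scale, so these numbers cannot rank the groups against one another. Still open, as far as these compounds go, is whether a basic amine or a carboxylic acid on this aromatic carbon, or a change to the two trifluoromethyl groups of the shared core, would lift the read-out above that floor.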